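Swapping an Oxadiazolyl Group for Cyclohexyl: Cytotoxicity Outlook

The source may hold more compounds than are shown below. What is called first, only, known or untested is meant among the compounds shown, and "the series" means these compounds.

Three compounds sharing one core have been examined in an ADME assay on CHO cells (Cricetulus griseus) for cytotoxicity; on this read-out lower numbers stand for stronger inhibition and higher numbers for weaker inhibition. Compound 1 `C/C(=N\O)c1nc2ccccc2s1` carries only a methyl group on the carbon with the double bond to nitrogen. In this assay compound 1 gives > 100000 nM, which is a limit of the assay rather than a number. Compound 3 `ON=C(c1nc2ccccc2s1)c1nc2ccccc2s1` carries a second copy of the core at the same carbon. In this assay compound 3 gives > 100000 nM, again a limit and not a measured number. Compound 2 `Cc1nnc(/C(=N\O)c2nc3ccccc3s2)o1` bears the 5-methyl-1,3,4-oxadiazol-2-yl group at that carbon, and in this assay compound 2 is recorded as "not determined" (no result reported), so no single number places it on the scale. What can be said of its surroundings is the limit of > 100000 nM in this assay, at which 2 of the 3 values shown sit.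

Compound 4 `O/N=C(/c1nc2ccccc2s1)C1CCCCC1` differs from compound 2 by cyclohexyl in place of 5-methyl-1,3,4-oxadiazol-2-yl on a carbon with a double bond to nitrogen. Among the compounds with values here, compound 2 has no number, and no step between measured compounds is known. No shift in this assay beyond the usual scatter is expected in either direction. For compound 4 in this assay a result of 100000 nM is therefore expected, with a plausible range from 30000 nM to 300000 nM, and most likely the assay will again report only a limit.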

Compound 4, half-maximal inhibitory concentration: 51600 nM
Compound 4: middle estimate off by 1.9-fold (0.29 log units), on the high side; the measured number falls inside the stated range.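

Within the data shown here, compound 4 is the one compound here for which this assay gives a number rather than a limit, which puts a group at this carbon on the scale for the first time. Cyclohexyl in place of methyl on a carbon with a double bond to nitrogen gives an at least 1.9-fold lower number from compound 1 to compound 4 (0.28 log units; that floor lies within the scatter), but this is only a floor set by the limit of compound 1, so the real size of the step could be larger and cannot be stated. The other compounds with a reported result give no number to set against compound 4, only a limit: the limit of > 100000 nM in this assay, at which 2 of the 4 values shown sit.

Compound 2 is recorded without a result, so the swap of 5-methyl-1,3,4-oxadiazol-2-yl for cyclohexyl, the change in the title, cannot be read, and neither can any step from compound 2. Going by these compounds, it also remains open whether the number for compound 4 goes with the ring of carbon only or with size alone, a question that a cyclopropyl group, a phenyl ring, a longer chain such as hexyl or an amine at this carbon could help to settle.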